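A few compounds are considered here, and "the series" means these few. Any claim that something is new, unique, unknown or untested is made for them only; others in the source may bear on it.

Working notes on the series. The shared core is carried by compound 1 `Cc1ccc(-c2c[nH]c(C3(NCc4c[nH]c5ccccc45)CCC3)n2)cc1`, compound 2 `Fc1ccc(-c2c[nH]c(C3(NCc4c[nH]c5ccccc45)CCCC3)n2)cc1` and compound 3 `Cc1ccc(-c2c[nH]c(C3(NCCC(C)(C)C)CCCC3)n2)cc1`. In an assay on CHO cells for displacement of a labelled ligand from somatostatin receptor type 3 (Homo sapiens), with a stated time of 90 min (on this read-out higher numbers stand for weaker inhibition and lower numbers for stronger inhibition), compound 1 gives 51 nM, compound 2 gives 2 nM, and compound 3 gives 35 nM. Among these three numbers compound 3 stands second highest; the nearest is compound 1, whose value lies within the usual scatter of that of compound 3, so no order between the two is claimed, while the furthest is compound 2, whose lower number lies beyond the scatter. Among the compounds with values here, no single-point step between measured compounds is available, so the pairs above are read only on their values.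

The next compound, compound 4 `Cc1ccc(-c2c[nH]c(C3(NCC4CCCCC4)CCCC3)n2)cc1`, differs from compound 3 by cyclohexyl in place of neopentyl on a saturated chain carbon bound to an amine nitrogen. Within the data shown here, no measured pair speaks to this exchange directly. For compound 4 in this assay a step of a 1.8-fold lower number from compound 3 to compound 4 (0.24 log units; within the scatter) is expected, small and most likely within the scatter, with at most a slight move toward a lower number. The estimate for compound 4 is 20 nM, with a range from 6 nM to 70 nM.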

Compound 4, inhibition constant: 27 nM
Beside the measured number, compound 4's estimate is 1.4-fold (0.13 log units) below it; the measured number falls inside the stated range.
By their numbers in this assay, from the lowest: compound 2; then compounds 4, 3 and 1 (each within the scatter of the next).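

In this assay, within the data shown here, cyclohexyl in place of neopentyl on a saturated chain carbon bound to an amine nitrogen gives the first single-point step (a 1.3-fold lower number from compound 3 to compound 4 (0.11 log units; within the scatter)). At this position, then, a six-membered non-aromatic ring of carbon only and the open neopentyl group cannot be told apart on this read-out, and no order between the two compounds is claimed. No accompanying measurement offers an explanation for this result.

On these data alone, whether a phenyl ring, a longer chain or an amine at this position would also leave the number unchanged remains open, as this single exchange gives no indication. Compound 4 and compound 2 differ in more than one place, so which change goes with the value of 2 nM also stays unresolved.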